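A few compounds are considered here, and "the series" means these few. Any claim that something is new, unique, unknown or untested is made for them only; others in the source may bear on it.

Working notes on the series. The shared core carries a two-ring fused system with two ring oxygens and a side chain ending in a dimethoxyphenoxy group. Compound 1 `COc1cccc(OC)c1OCCNC[C@H]1Oc2ccccc2O[C@H]1C` bears a methyl on the saturated ring carbon and in a functional assay for antagonist activity at Adrenergic receptor alpha-1 (Rattus norvegicus) (a higher number here means weaker binding, a lower number tighter binding), compound 1 gives 3.16 nM. Compound 2 `COc1cccc(OC)c1OCCNC[C@H]1Oc2ccccc2O[C@H]1C1CCCCC1` carries cyclohexyl in place of that methyl, and compound 2 gives 631 nM; the step is a 200-fold higher number from compound 1 to compound 2 (2.30 log units; beyond the scatter). Compound 3 `COc1cccc(OC)c1OCCNC[C@H]1Oc2ccccc2O[C@@H]1C1CCCCC1` shares all atoms and bonds with compound 2 and compound 3 gives 813 nM; the step of a 1.3-fold higher number from compound 2 to compound 3 (0.11 log units; within the scatter) is within the scatter, consistent with the fact that compounds 2 and 3 differ only in the configuration as drawn. Compound 3 thus stands at the upper end of the three numbers, separated from compound 2 only by scatter and far above compound 1.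

Compound 4 `COc1ccc([C@H]2Oc3ccccc3O[C@@H]2CNCCOc2c(OC)cccc2OC)cc1` is the next step: 4-methoxyphenyl in place of cyclohexyl on a saturated ring carbon. Among the compounds with values here, two measured steps bear on it. The large step from methyl to cyclohexyl, a 200-fold higher number from compound 1 to compound 2 (2.30 log units; beyond the scatter), shows that a six-membered ring on this carbon moves the number strongly upward, whereas the configuration change, a 1.3-fold higher number from compound 2 to compound 3 (0.11 log units; within the scatter), did nothing beyond scatter. Swapping one six-membered ring for another of similar size is expected to leave compound 4 near compound 3, so the expected step is a 2.0-fold lower number from compound 3 to compound 4 (0.31 log units; beyond the scatter), not clearly beyond the scatter. Compound 4 is therefore estimated at 400 nM, with a range from 80 nM to 2000 nM.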

Compound 4, dissociation constant: 2.14 nM
Beside the measured number, compound 4's estimate is 190-fold (2.27 log units) above it; measured number below the stated range.
By their numbers in this assay, from the lowest: compounds 4 and 1 (each within the scatter of the next); then compounds 2 and 3 (each within the scatter of the next).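

In this assay, within the data shown here, the change to 4-methoxyphenyl is a 380-fold lower number from compound 3 to compound 4 (2.58 log units; beyond the scatter), so a large ring on this saturated ring carbon does not by itself give a high number, which the earlier compounds could not show. Cyclohexyl and 4-methoxyphenyl each bring a six-membered ring of carbon, yet the two groups sit at opposite ends of the series: compound 3 gives 813 nM and compound 4 gives 2.14 nM, a value within the scatter of the one for compound 1, which carries only a methyl. The one available note on these compounds concerns configuration in compounds 2 and 3 and does not bear on this step, which therefore stays unexplained.

The change replaces a non-aromatic ring with an aromatic one and adds a methoxy group in a single move, and the compounds shown cannot separate these two parts. On these data alone, an unsubstituted phenyl on this carbon would divide them, while a pyridine ring, an amine in place of the methoxy group, and the other configuration at this carbon with an aromatic ring remain open.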